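Swapping Chloro for Methyl on the Pendant Phenyl

The source may report more compounds than this note shows. Statements on the series, on what has been measured and on what is new or still open speak of the compounds shown alone.

Compound 1 `CCN(Cc1ccccc1)C(=O)c1nc(-c2ccccc2Cl)c2ccccc2n1` gives 0.235 nM in an assay on cell membranes from kidney for displacement of a labelled ligand from Translocator protein (Rattus norvegicus); on this read-out lower numbers stand for stronger inhibition and higher numbers for weaker inhibition. Within the data shown here, compound 2 `CCN(Cc1ccccc1)C(=O)c1nc(-c2ccc(Cl)cc2)c2ccccc2n1` gives 0.762 nM, the higher of the two numbers, and the only measured step, a 3.2-fold higher number from compound 1 to compound 2 (0.51 log units; beyond the scatter), moves the chloro to another place rather than exchanging it. Compound 3 `CCN(Cc1ccccc1)C(=O)c1nc(-c2ccc(C)cc2)c2ccccc2n1` differs from compound 2 by methyl in place of chloro on an aromatic carbon. Among the measured compounds shown here, no measured step trades chloro for methyl, so the change is expected to stay within the scatter. For compound 3 the estimate in this assay is 0.9 nM, ranging from 0.3 nM to 3 nM. The expected step is a 1.2-fold higher number from compound 2 to compound 3 (0.07 log units; within the scatter).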

Compound 3, inhibition constant: 1.49 nM
Estimate against measurement, compound 3: 1.7-fold (0.22 log units) below; measured number inside the range.
By their numbers in this assay, from the lowest: compound 1; then compounds 2 and 3 (each within the scatter of the next).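

On this aromatic carbon, methyl and chloro cannot be told apart in this assay, where the exchange gives a 2.0-fold higher number from compound 2 to compound 3 (0.29 log units; within the scatter). The change that replaces 2-chlorophenyl with 4-methylphenyl is larger, with a 6.3-fold higher number from compound 1 to compound 3 (0.80 log units; beyond the scatter), so compound 1 stays ahead of compound 3 beyond the scatter. No measured evidence here explains either step.

As far as these compounds go, whether an amine, a methoxy group or a carboxylic acid on the same carbon would also stay close to compound 2 remains open. So does the effect of moving the methyl elsewhere on the ring.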